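Replacing a Ring Hydrogen with a Second Piperidinyl Ether

This account rests on a few compounds, and the source may have more. Where it says the series, first, only, none or still open, it means among the compounds named here.

Compound 1, `COc1ccc(C(=O)Nc2cc3ccc(OC4CCN(C)CC4)c(C)c3oc2=O)cc1CC=C(C)C`: 1410 nM
Compound 2, `C#CCOc1ccc(C(=O)Nc2cc3ccc(OC4CCN(C)CC4)c(C)c3oc2=O)cc1CC=C(C)C`: 1400 nM
Compound 3, `CC(C)=CCc1cccc(C(=O)Nc2cc3ccc(OC4CCN(C)CC4)c(C)c3oc2=O)c1`: 1680 nM

Of the compounds shown here, three sharing one core have been tested in a functional assay on SK-BR-3 cells (Homo sapiens) for antiproliferative activity; a lower number here means a stronger inhibitor, a higher number a weaker inhibitor. Compound 3 gives the highest of the three numbers, but its step to compound 1 and its step to compound 2 both lie within the scatter, so the three are, in effect, indistinguishable.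

Compound 4, `CC(C)=CCc1cc(C(=O)Nc2cc3ccc(OC4CCN(C)CC4)c(C)c3oc2=O)ccc1OC1CCN(C)CC1`, has not yet been measured. It differs from compound 3 in one place: (1-methylpiperidin-4-yl)oxy in place of hydrogen on an aromatic carbon, the entering group standing on the aromatic carbon para to a large group and ortho to the 3-methylbut-2-en-1-yl group.

Within the data shown here, two measured steps touch the same aromatic carbon. Going from a methoxy to a hydrogen there gave a 1.2-fold higher number from compound 1 to compound 3 (0.08 log units; within the scatter), and going from a propargyloxy to a hydrogen gave a 1.2-fold higher number from compound 2 to compound 3 (0.08 log units; within the scatter). Both of these substituents, small and larger, left the number unchanged within the scatter. The entering group here is bulkier than either, so the evidence is only indirect, but nothing measured points to a shift in either direction.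

Compound 4 is therefore expected to give 1500 nM, within a range of 600 nM to 3800 nM. This estimate means a step of a 1.1-fold lower number from compound 3 to compound 4 (0.05 log units; within the scatter), expected to stay within the scatter.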

Compound 4, half-maximal inhibitory concentration: 210 nM
The estimate for compound 4 lay 7.1-fold (0.85 log units) above the measured number, and the stated range ends above it.
By their numbers in this assay, from the lowest: compound 4; then compounds 2, 1 and 3 (each within the scatter of the next).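

In this assay, placing (1-methylpiperidin-4-yl)oxy on the aromatic carbon ortho to the 3-methylbut-2-en-1-yl group gives an 8.0-fold lower number from compound 3 to compound 4 (0.90 log units; beyond the scatter) and so shows that this carbon is not indifferent to what it carries, which hydrogen, methoxy and propargyloxy alone had not revealed. Changing only the group on the oxygen tells the same story: 1-methylpiperidin-4-yl in place of propargyl gives a 6.7-fold lower number from compound 2 to compound 4 (0.82 log units; beyond the scatter) and 1-methylpiperidin-4-yl in place of methyl gives a 6.7-fold lower number from compound 1 to compound 4 (0.83 log units; beyond the scatter), so an oxygen at this carbon is not enough by itself, and the gain depends on what that oxygen carries. No measurement shown bears on why this one group stands apart from the other two ethers.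

The compounds shown leave open which part of the entering group matters: its nitrogen, the methyl on that nitrogen, or the ring as a whole. A cyclohexyloxy group, a piperidin-4-yloxy group without the methyl, or an open-chain 2-(dimethylamino)ethoxy group at this carbon would begin to separate these possibilities.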